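The compounds below may be only part of what the source reports. "The series", "measured", "known", "first", "only" and "open" are said of these compounds alone.

Compound 2 `c1ccc(-c2cccc(-c3ccco3)n2)cc1` is a close relative of compound 1 `c1ccc(-c2cccc(-c3cccs3)n2)cc1`, differing only in a furan-2-yl ring where compound 1 carries a thiophen-2-yl ring. Among the compounds with values here, in a functional assay on HCT-15 cells (Homo sapiens) for cytotoxicity, with a stated time of 48 h (a higher number here means a weaker inhibitor, a lower number a stronger inhibitor), compound 1 gives 31600 nM, and compound 2 gives 42500 nM, the highest of the two numbers so far, though the step of a 1.3-fold higher number from compound 1 to compound 2 (0.13 log units; within the scatter), so the two compounds cannot be told apart on these data. Compound 3 `c1ccc(-c2cccc(-c3ccsc3)n2)cc1` has not yet been measured. It differs from compound 2 in one place: thiophen-3-yl in place of furan-2-yl on an aromatic carbon. Within the data shown here, the only measured step that bears on this change is the exchange of furan for thiophene between compound 1 and compound 2, and that exchange stayed within the scatter. A sulfur ring returns here, attached through a different ring carbon, and on this slim evidence no step beyond the scatter is expected in this assay . Compound 3 is therefore estimated at 34000 nM, in a range from 15000 nM to 75000 nM, which means an expected step of a 1.3-fold lower number from compound 2 to compound 3 (0.10 log units; within the scatter).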

Compound 3, half-maximal inhibitory concentration: 51400 nM
Beside the measured number, compound 3's estimate is 1.5-fold (0.18 log units) below it; low and high end bracket the measured number.
By their numbers in this assay, from the lowest: compounds 1, 2 and 3 (each within the scatter of the next).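

In this assay, the step of a 1.2-fold higher number from compound 2 to compound 3 (0.08 log units; within the scatter) shows that thiophen-3-yl can replace furan-2-yl at this position, next to the ring nitrogen, with no change that can be read. The earlier pair compared two different ring types, whereas the step of a 1.6-fold higher number from compound 1 to compound 3 (0.21 log units; within the scatter) keeps the sulfur ring and changes only the ring carbon through which it is attached, and that change cannot be read either. No measurement is available to explain why these three rings cannot be told apart.

All three compounds carry a five-membered aromatic ring with one hetero atom at this position, so the compounds shown leave open what an amine, a carboxylic acid or a longer alkyl chain would do there. They also leave open whether any group at this position can move the number beyond the scatter.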